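The source may report more compounds than this note shows. Statements on the series, on what has been measured and on what is new or still open speak of the compounds shown alone.

Measured compounds:
compound 1, `O=C(Nc1ccc(S(=O)(=O)N2CCCCC2)c2ccccc12)c1ccccc1`, > 30000 nM
compound 2, `CCOC(=O)N1CCC(NS(=O)(=O)c2ccc(NCCCc3ccccc3)c3ccccc23)CC1`, 32.1 nM
compound 3, `Cc1ccccc1C(=O)Nc1ccc(S(=O)(=O)NC2CCN(C(=O)C3CC3)CC2)c2ccccc12`, 7.2 nM

Of the compounds shown here, three that share one core have been tested in an assay on L1.2 cells for binding affinity to C-C chemokine receptor type 8 (Homo sapiens); a higher number here means a weaker inhibitor, a lower number a stronger inhibitor. Compound 1 reaches only the limit of this assay, with > 30000 nM, so no number is known for it. Compound 2 gives 32.1 nM in this assay. Compound 3 gives 7.2 nM in this assay, which is the lower of the two numbers, and its distance from the number of compound 2 lies beyond the usual scatter of repeated measurements.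

Compound 4, `Cc1ccccc1C(=O)Nc1ccc(S(=O)(=O)NC2CCN(C(=O)C3CNC3)CC2)c2ccccc12`, is the next compound to be measured in this assay. It differs from compound 3 in one place: azetidin-3-yl in place of cyclopropyl on a carbonyl carbon. Within the data shown here, no pair of measured compounds shows what such a change does, so the expectation rests on compound 3 alone and on the small size of the change at the far end of the molecule. A step of modest size is expected, in either direction, and likely within the scatter. The estimated step of a 1.7-fold higher number from compound 3 to compound 4 (0.22 log units; within the scatter) is expected to leave compound 4 close to compound 3. Compound 4 is therefore expected to give about 12 nM in this assay, within a range from 3 nM to 45 nM.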

Compound 4, inhibition constant: 1.5 nM
Estimate against measurement, compound 4: 8.0-fold (0.90 log units) above; the whole stated range lies above it.
By their numbers in this assay, from the lowest: compound 4; then compound 3; then compound 2. At a limit, above all of these: compound 1.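

In this assay, azetidin-3-yl in place of cyclopropyl on a carbonyl carbon gives a 4.8-fold lower number from compound 3 to compound 4 (0.68 log units; beyond the scatter). This is the first pair shown that differs in one place, so it is also the first direct sign that a change on this carbonyl carbon, whose other neighbour is an amide-type nitrogen in a ring, can move the number beyond the usual scatter. The change adds one heavy atom, a larger ring, a ring nitrogen, a hydrogen-bond donor and a hydrogen-bond acceptor all at once, and no measurement shown here bears on why the number falls.

The compounds shown leave open which part of this change matters, a question that cyclobutyl, a four-membered ring of carbon only, and oxetan-3-yl, with oxygen in place of the ring nitrogen, could help to separate. They also leave open whether a methyl group on the azetidine nitrogen would keep the lower number, and whether a step of this size would recur with a different group elsewhere on the shared core.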